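Hydrazone aryl exchange in a shared-core cytotoxicity series

The source may hold more compounds than are shown below. What is called first, only, known or untested is meant among the compounds shown, and "the series" means these compounds.

Measured so far:
Compound 1 `NS(=O)(=O)c1ccc(Nc2nc(N/N=C/c3ccc(C(F)(F)F)cc3)nc(Nc3ccccc3)n2)cc1` gives 40300 nM in a functional assay on EKVX cells (Homo sapiens) for inhibition, read by sulforhodamine B assay, with a stated time of 48 h; on this read-out higher numbers stand for lower toxicity in this test and lower numbers for higher toxicity in this test.
Compound 2 `Cc1nn(-c2ccccc2)cc1/C=N/Nc1nc(Nc2ccccc2)nc(Nc2ccc(S(N)(=O)=O)cc2)n1` gives 35100 nM in this assay.

Among the measured compounds shown here, compound 2 and compound 1 cannot be told apart on these numbers: the only measured step, a 1.1-fold lower number from compound 1 to compound 2 (0.06 log units; within the scatter), lies within the scatter. Both carry the same core and differ only in the aryl group attached to the carbon with a double bond to nitrogen.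

Compound 3 `NS(=O)(=O)c1ccc(Nc2nc(N/N=C/c3ccccn3)nc(Nc3ccccc3)n2)cc1` is the next variation at that same position: pyridin-2-yl in place of 3-methyl-1-phenyl-1H-pyrazol-4-yl on a carbon with a double bond to nitrogen.

For the measured compounds named here, the one step that bears on this change, a 1.1-fold lower number from compound 1 to compound 2 (0.06 log units; within the scatter), swapped one aryl group for another at the same carbon and moved the number by less than the scatter. With a single such precedent and no further data, the expected step of a 1.1-fold higher number from compound 2 to compound 3 (0.03 log units; within the scatter) in this assay is none beyond the scatter, in no preferred direction. For compound 3 the estimate in this assay is 38000 nM, with a range from 14000 nM to 95000 nM.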

Compound 3, concentration lethal to 50% of the cells: > 100000 nM
Compound 3: only a limit was reported; the forecaster's own chance of this, stated with the estimate: 10%; middle value at least 2.6-fold (0.42 log units) from the limit.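

Notes on the aryl position: this position on the carbon with a double bond to nitrogen is not indifferent to the group placed there, since the exchange from compound 1 to compound 2 stayed within the scatter, at a 1.1-fold lower number from compound 1 to compound 2 (0.06 log units; within the scatter). Pyridin-2-yl moves the number clearly, to lower toxicity in this test, with an at least 2.8-fold higher number from compound 2 to compound 3 (0.45 log units; beyond the scatter) and an at least 2.4-fold higher number from compound 1 to compound 3 (0.39 log units; beyond the scatter). In this assay, compound 3 gives only a limit, not a number, so both steps are minimum sizes: the limit of > 100000 nM in this assay, at which 1 of the 3 values shown sits.

The three compounds leave open how far the true value of compound 3 lies past that limit. They also leave open whether the pyridine nitrogen matters, since an unsubstituted phenyl or a pyridin-4-yl group would be needed to separate its contribution from that of the aryl exchange as a whole.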